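From Chloro to Methoxy: What to Expect for Compound 4

The source may report more compounds than this note shows. Statements on the series, on what has been measured and on what is new or still open speak of the compounds shown alone.

Of the compounds shown here, three have been measured in a functional assay on cells for positive allosteric modulation of G-protein coupled receptor 68 (Homo sapiens), read by a luciferase reporter and cAMP accumulation, with a stated time of 30 min, at pH 6.8 and pH 8.3, in the presence of a further agent that is not named here; a higher number here means a more potent compound, by a factor of ten per unit of this negative logarithm, a lower number a less potent compound. Compound 1 `Nc1nc(NCc2ccccc2)nc(-c2ccc(F)cc2CO)n1` gives 4.58, compound 2 `Nc1nc(NCc2ccccc2)nc(-c2ccc(Cl)cc2CO)n1` gives 4.76, and compound 3 `COc1cccc(-c2nc(N)nc(NCc3ccccc3)n2)c1CO` gives 4.16. Compound 2 has the highest of the three numbers, though compound 1 lies within the usual scatter of it, while compound 3 lies beyond it. Compound 4 `COc1ccc(-c2nc(N)nc(NCc3ccccc3)n2)c(CO)c1` differs from compound 2 by methoxy in place of chloro on an aromatic carbon. For the measured compounds named here, the only measured step, a number 0.18 log units higher from compound 1 to compound 2 (within the scatter), exchanged one halogen for another and stayed within the scatter, so it offers little guidance here. Compound 3, which also carries a methoxy group, shows the lowest number of the three, which suggests a modest downward drift. Compound 4 is therefore expected to reach about 4.45, estimated between 3.95 and 4.95, an expected step of a number 0.31 log units lower from compound 2 to compound 4 (beyond the scatter).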

Compound 4, negative logarithm of the antagonist equilibrium constant: 4.12
Compound 4: middle estimate off by 0.33 log units, on the high side; the range from low to high includes it.
By their numbers in this assay, from the lowest: compounds 4 and 3 (each within the scatter of the next); then compounds 1 and 2 (each within the scatter of the next).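

Putting methoxy on this carbon, para to a large group, lowers the number in this assay whichever halogen it replaces: the steps are a number 0.64 log units lower from compound 2 to compound 4 (beyond the scatter) and a number 0.46 log units lower from compound 1 to compound 4 (beyond the scatter). For the compounds shown here, exchanging one halogen for the other had stayed within the scatter, so this position distinguishes methoxy from the halogens in a way that the earlier compounds could not show. Nothing available explains the drop. The compounds shown leave open how an amine, a carboxylic acid or a longer chain such as ethoxy would fare on this carbon.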